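A few compounds are considered here, and "the series" means these few. Any claim that something is new, unique, unknown or untested is made for them only; others in the source may bear on it.

Three compounds have been measured in a functional assay on RAW264.7 cells (Mus musculus), with a stated time of 3 days; a lower number here means a stronger inhibitor, a higher number a weaker inhibitor:
Compound 1, `COc1cnc(-c2ccccn2)nc1N1CCCC1`, gives 150 nM.
Compound 2, `COc1cnc(-c2ccccn2)nc1NCc1ccccc1Cl`, gives 520 nM.
Compound 3, `COc1cnc(-c2ccccn2)nc1NC1CCCC1`, gives 570 nM.

Compound 2 stands with the second highest of these three numbers. Its value and that of compound 3 lie within the scatter of each other, so the two cannot be told apart; compound 1 gives a lower number than compound 2 by a margin beyond the scatter.

Compound 4, `COc1cnc(-c2ccccn2)nc1NCc1ccccc1C`, differs from compound 2 in one place: methyl in place of chloro on an aromatic carbon.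

Within the data shown here, the only step measured so far, a 3.8-fold higher number from compound 1 to compound 3 (0.58 log units; beyond the scatter), concerns a different part of the shared core and a different kind of exchange, so it does not bear directly on this change. Among the measured compounds shown here, no measured pair swaps one group for another on the benzyl ring. With nothing in the data pointing either way, the step from compound 2 to compound 4 is expected to stay within the scatter, no change at the digits printed from compound 2 to compound 4 (within the scatter). Compound 4 is therefore estimated at 520 nM in this assay, with a likely range from 250 nM to 1100 nM.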

Compound 4, half-maximal inhibitory concentration: 220 nM
For compound 4 the middle estimate is 2.4-fold (0.37 log units) above the measured one; measured number outside the range, below it.
By their numbers in this assay, from the lowest: compounds 1 and 4 (each within the scatter of the next); then compounds 2 and 3 (each within the scatter of the next).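

In this assay, methyl in place of chloro gives a 2.4-fold lower number from compound 2 to compound 4 (0.37 log units; beyond the scatter), so this place on the six-membered aromatic ring responds to which small group it carries. The step is modest, yet it separates two groups that match on every count computed here: each has one heavy atom, no ring, no hydrogen-bond donors or acceptors, and no net charge. Nothing available explains why the number moves with this exchange.

The compounds shown leave open how a fluoro, methoxy or trifluoromethyl group would compare at this same place, and where a plain phenyl ring with no group there would fall. They also leave open whether methyl in place of chloro would give a similar step on another carbon of that ring.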